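The compounds below may be only part of what the source reports. "The series", "measured", "known", "first", "only" and "open" are said of these compounds alone.

Measured so far in an ADME assay on PNT1A cells (Homo sapiens) for cytotoxicity, read by MTT assay, with a stated time of 48 h; a lower number here means a stronger inhibitor, a higher number a weaker inhibitor:
- Compound 1 `COc1cc(O)ccc1N1CCN(CC(O)COc2cccc3ccccc23)CC1`: > 50000 nM (a limit)
- Compound 2 `COc1cc(O)ccc1N1CCN(CC(O)COc2ccc(O)c3ccccc23)CC1`: 37200 nM
- Compound 3 `Oc1ccccc1N1CCN(CC(O)COc2ccc(O)c3ccccc23)CC1`: 37400 nM

In this assay compound 1 gives > 50000 nM, which is a limit of the assay and not a number. Compound 1 thus stands at the limit of > 50000 nM in this assay, at which 1 of the 3 values shown sits. The other two compounds both return true numbers, and these lie within the scatter of each other.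

Compound 4 `Oc1ccccc1N1CCN(CC(O)COc2cccc3ccccc23)CC1` has not been measured yet. It keeps the core of compound 1 and alters one group: 2-hydroxyphenyl in place of 4-hydroxy-2-methoxyphenyl on an amine nitrogen in a ring.

The same exchange has already been measured once, on a core that carries one more hydroxy: a 1.0-fold higher number from compound 2 to compound 3 (0.00 log units; within the scatter). That step is the closest guide, and it lies within the scatter. The other step, an at least 1.3-fold lower number from compound 1 to compound 2 (0.12 log units; that floor lies within the scatter), is the hydroxy addition that links the two cores, and its floor is also within the scatter. Among the measured compounds shown here, this is only one matched pair, so the guidance is thin, but it points to no real shift in this assay. Because of a 1.0-fold higher number from compound 2 to compound 3 (0.00 log units; within the scatter) the expected change is none beyond the scatter, and the expected step is a number no higher from compound 1 to compound 4 (the limit leaves the size open). Compound 4 may well be reported only as a limit too. For compound 4 the estimate is 50000 nM, with an expected range from 30000 nM to 100000 nM.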

Compound 4, half-maximal inhibitory concentration: 22200 nM
Compound 4: middle estimate off by 2.3-fold (0.35 log units), on the high side, outside the stated range (below it).
By their numbers in this assay, from the lowest: compounds 4, 2 and 3 (each within the scatter of the next). At a limit, above all of these: compound 1.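

In this assay, the exchange of 4-hydroxy-2-methoxyphenyl for 2-hydroxyphenyl on the amine nitrogen in a ring now gives a step beyond the scatter on the core of compound 1, an at least 2.2-fold lower number from compound 1 to compound 4 (0.35 log units; beyond the scatter), while the same exchange on the core with one more hydroxy gave no shift beyond the scatter, though the two cannot be firmly told apart: the same change on two cores in this assay, a 1.0-fold higher number (0.00 log units; within the scatter) from compound 2 to compound 3 and an at least 2.2-fold lower number (0.35 log units; beyond the scatter) from compound 1 to compound 4; the limit leaves it open whether they differ

Compound 1 gives > 50000 nM, which is a limit and not a number, so the size of that step remains a floor.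

With the 2-hydroxyphenyl group in place, removing the extra hydroxy from the core gives a 1.7-fold lower number from compound 3 to compound 4 (0.23 log units; within the scatter), which lies within the scatter, and the hydroxy step on the other core cannot be firmly compared with it: the same change on two cores in this assay, an at least 1.3-fold lower number (0.12 log units; that floor lies within the scatter) from compound 1 to compound 2 and a 1.7-fold higher number (0.23 log units; within the scatter) from compound 4 to compound 3; the limit leaves it open whether they differ

The exchange removes a methoxy and also alters where the hydroxy sits, and the compounds shown do not separate these two changes. A 2-methoxyphenyl group or a plain phenyl group on the same nitrogen would help show which part of the exchange goes with the lower number.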